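Replacing hydroxycarbamoyl in compound 2

This account rests on a few compounds, and the source may have more. Where it says the series, first, only, none or still open, it means among the compounds named here.

Compound 2 (`Cn1cc(-c2ccccc2Oc2ccccc2)c2cc(C(=O)NCCCC(=O)NO)[nH]c2c1=O`) gives 380 nM in a functional assay on MV4-11 cells (Homo sapiens) for antiproliferative activity, read by CCK-8 assay, with a stated time of 72 h (a higher number here means a weaker inhibitor, a lower number a stronger inhibitor), and lies within the scatter of compound 3 (`Cn1cc(-c2ccccc2Oc2ccccc2)c2cc(C(=O)NCc3ccc(C(=O)NO)cc3)[nH]c2c1=O`), which gives 570 nM with no order between them. Compound 1 (`CC(C)Oc1ccc(C(C)(C)O)cc1-c1cn(C)c(=O)c2[nH]c(C(=O)NCCCCCCC(=O)NO)cc12`) gives 160 nM and stands lower than compound 2, beyond the scatter. Compound 4 (`Cn1cc(-c2ccccc2Oc2ccccc2)c2cc(C(=O)NCCCCCC(=O)Nc3ccccc3N)[nH]c2c1=O`) carries 2-((2-aminophenyl)carbamoyl)ethyl in place of hydroxycarbamoyl on a saturated chain carbon, three bonds along the chain from an amide-type nitrogen. Among the measured compounds shown here, the one measured step (a 1.5-fold higher number from compound 2 to compound 3 (0.18 log units; within the scatter)) keeps hydroxycarbamoyl, as do compound 1, compound 2 and compound 3, so no measured step covers this replacement. A higher number is expected, as an estimated step (a 2.6-fold higher number from compound 2 to compound 4 (0.42 log units; beyond the scatter)) in this assay with wide uncertainty. The expected value for compound 4 is 1000 nM (range 300 nM to 4000 nM).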

Compound 4, half-maximal inhibitory concentration: 70 nM
Compound 4: middle estimate off by 14-fold (1.15 log units), on the high side, and the stated range ends above it.
By their numbers in this assay, from the lowest: compound 4; then compound 1; then compounds 2 and 3 (each within the scatter of the next).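

In this assay, hydroxycarbamoyl is not required at this place on the chain: 2-((2-aminophenyl)carbamoyl)ethyl in its place gives a 5.4-fold lower number from compound 2 to compound 4 (0.73 log units; beyond the scatter), a gain beyond the scatter. Compounds 1, 2 and 3 all keep hydroxycarbamoyl, so only compound 4 shows that another group can serve here. Nothing measured accounts for this step.

Going by these compounds, whether a carboxylic acid or a 2-hydroxyphenyl amide at the same place would hold this level remains open. Also open, on these data alone, is whether the gain carries over to the core of compound 1.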